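Working notes: liver microsome stability across four compounds

The source may hold more compounds than are shown below. What is called first, only, known or untested is meant among the compounds shown, and "the series" means these compounds.

Measured so far:
- compound 1 `CN(C[C@H]1Cc2c(cccc2N2C[C@@H]3C[C@H]2CN3)CN1)[C@H]1CCCc2cccnc21`: in an ADME assay on microsomes from liver (Mus musculus) for metabolic stability, read by LC-MS, with a stated time of 10 min (on this read-out higher numbers stand for a more stable compound and lower numbers for a less stable compound), compound 1 gives 36.3%
- compound 2 `C[C@@H]1CN(c2cccc3c2C[C@H](CN(C)[C@H]2CCCc4cccnc42)NC3)C[C@H](C)N1C`: in this assay compound 2 gives 39.6%
- compound 3 `CN(C[C@H]1Cc2c(cccc2N2CCNC(C)(C)C2)CN1)[C@H]1CCCc2cccnc21`: in this assay compound 3 gives 44%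

Compound 3 has the highest of the three numbers, but its separation from compound 2 (a number 4.4 percentage points higher from compound 2 to compound 3 (within the scatter)) and from compound 1 (a number 7.7 percentage points higher from compound 1 to compound 3 (within the scatter)) is within the scatter, so no order among the three can be claimed. The step of a number 3.3 percentage points higher from compound 1 to compound 2 (within the scatter) is likewise within the scatter.

Compound 4 `CN(C[C@H]1Cc2c(cccc2N2CCN3CCC[C@H]3C2)CN1)[C@H]1CCCc2cccnc21` is not yet measured. It differs from compound 3 at the same position where compounds 1, 2 and 3 differ from one another: a group of 9 heavy atoms (7 carbon, 2 nitrogen; one five-membered non-aromatic ring with 1 hetero atom, one six-membered non-aromatic ring with 2 hetero atoms) in place of a group of 8 heavy atoms (6 carbon, 2 nitrogen; one six-membered non-aromatic ring with 2 hetero atoms), on an aromatic carbon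

Every measured step at this position stayed within the scatter, so a change at this position has not so far moved the number beyond it. On that basis compound 4 is expected to stay close to compound 3, with an expected step of a number 4 percentage points lower from compound 3 to compound 4 (within the scatter) and no direction beyond the scatter. The estimate for compound 4 in this assay is 40%, with a range from 22% to 58%.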

Compound 4, percent of the compound remaining: 40.1%
The estimate for compound 4 lay 0.1 percentage points below the measured number, and the stated range covers the measured number.
By their numbers in this assay, from the lowest: compounds 1, 2, 4 and 3 (each within the scatter of the next).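

A fused pair of rings, one five-membered and one six-membered, with 1 defined stereocentre and 0 hydrogen-bond donors, is tolerated on this aromatic carbon in this assay in place of 3,3-dimethylpiperazin-1-yl with its 1 donor: the step is a number 3.9 percentage points lower from compound 3 to compound 4 (within the scatter). The two other steps to the new group also stay inside the scatter, at a number 0.5 percentage points higher from compound 2 to compound 4 (within the scatter) and a number 3.8 percentage points higher from compound 1 to compound 4 (within the scatter), so all six steps among the four groups now show no separation at this place. Nothing available bears on the reason for these small steps.

All four groups shown are non-aromatic rings carrying 2 nitrogen atoms. Still open, from the compounds shown here alone, are a morpholine ring or a carboxylic acid on this carbon, and the mirror-image form of the fused group.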